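This account rests on a few compounds, and the source may have more. Where it says the series, first, only, none or still open, it means among the compounds named here.

Going by the values given here, compound 2 `Cc1noc(C)c1-c1cnc(N)c(Oc2ccc(C(=O)Nc3ccc(Cl)cc3)cc2)n1` gives 14400 nM in a functional assay on HepG2 cells (Homo sapiens) for inhibition, read by MTT assay, with a stated time of 72 h (on this read-out lower numbers stand for stronger inhibition and higher numbers for weaker inhibition), the higher of the two numbers measured so far, while compound 1 `Cc1noc(C)c1-c1cnc(N)c(Oc2ccc(C(=O)NC3CCCC3)cc2)n1` sits within the scatter of it at 12800 nM. Among the compounds with values here, the single step measured, a 1.1-fold higher number from compound 1 to compound 2 (0.05 log units; within the scatter), exchanges the group on the amide-type nitrogen and stays within the scatter. Compound 3 `Cc1noc(C)c1-c1cnc(N)c(Oc2ccc(C(=O)Nc3ccc(Cl)cn3)cc2)n1` has not yet been measured; it differs from compound 2 by 5-chloropyridin-2-yl in place of 4-chlorophenyl on an amide-type nitrogen. Within the data shown here, no measured step covers this particular exchange, and the only step at this position, that from compound 1 to compound 2, lay within the scatter, so the number is expected to stay where compound 2 stands, with a 1.0-fold lower number from compound 2 to compound 3 (0.01 log units; within the scatter) expected to be no larger than the usual scatter. Compound 3 is therefore estimated at 14000 nM in this assay, with a range from 5000 nM to 40000 nM.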

Compound 3, half-maximal inhibitory concentration: 35600 nM
Compound 3: the middle estimate sits 2.5-fold (0.41 log units) below what was measured, and the stated range covers the measured number.
By their numbers in this assay, from the lowest: compounds 1 and 2 (each within the scatter of the next); then compound 3.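

In this assay the amide-type nitrogen now responds to the group it carries, which the earlier exchange did not show: with 5-chloropyridin-2-yl in place of 4-chlorophenyl, there is a 2.5-fold higher number from compound 2 to compound 3 (0.39 log units; beyond the scatter), a modest step. With the same group in place of cyclopentyl, there is a 2.8-fold higher number from compound 1 to compound 3 (0.44 log units; beyond the scatter), also modest and in the same direction, towards weaker inhibition. The data shown offer no explanation for this shift.

Both aromatic groups shown carry chlorine, so it remains open whether the entering ring nitrogen would give the same step with a methoxy group or a plain hydrogen in place of that chlorine. Also open, going by these compounds, is how a longer chain or an amine-bearing group on this amide-type nitrogen would compare with cyclopentyl.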